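The source may hold more compounds than are shown below. What is called first, only, known or untested is meant among the compounds shown, and "the series" means these compounds.

In a functional assay on HepG2 cells (Homo sapiens) for antiproliferative activity, read by MTT assay, with a stated time of 48 h (a lower number here means a stronger inhibitor, a higher number a weaker inhibitor), compound 1 `O=C(/C=C/c1ccc(/C=C/C(=O)c2cccc(Cl)c2)o1)NO` gives 54500 nM. Compound 2 `O=C(NO)c1ccc(/C=C/c2ccccc2O)o1` gives 54000 nM and compound 3 `O=C(/C=C/c1ccc(/C=C/C(=O)c2cc(Cl)ccc2Cl)o1)NO` gives 48300 nM, so compound 1 stands level with both, all three values lying within the scatter of one another. Compound 4 `Cc1ccc(C(=O)/C=C/c2ccc(/C=C/C(=O)NO)o2)cc1` has not yet been measured. It differs from compound 1 in one place: 4-methylphenyl in place of 3-chlorophenyl on a carbonyl carbon. In words, 4-methylphenyl stands in place of 3-chlorophenyl on a carbonyl carbon. Among the compounds with values here, the one measured step that bears on this change is chloro in place of hydrogen on an aromatic carbon, a 1.1-fold lower number from compound 1 to compound 3 (0.05 log units; within the scatter). Within the data shown here, no measured compound carries 4-methylphenyl, so the data give only indirect guidance. With compound 3 at 48300 nM, no step beyond the scatter is expected in this assay. The expected step is a 1.2-fold lower number from compound 1 to compound 4 (0.08 log units; within the scatter). For compound 4 the estimated value is 45000 nM, with an expected range from 18000 nM to 100000 nM.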

Compound 4, half-maximal inhibitory concentration: 16000 nM
Compound 4: middle estimate off by 2.8-fold (0.45 log units), on the high side; measured number outside the range, below it.
By their numbers in this assay, from the lowest: compound 4; then compounds 3, 2 and 1 (each within the scatter of the next).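

In this assay, the aryl group on this carbonyl carbon proved able to move the number beyond the scatter (a 3.4-fold lower number from compound 1 to compound 4 (0.53 log units; beyond the scatter)), whereas the earlier chloro step on the ring stayed within it. The size of the group does not separate the two compounds: 3-chlorophenyl and 4-methylphenyl have the same heavy-atom count, and neither has hydrogen-bond donors or acceptors, so the modest step comes with a change of substituent and of its ring position together. No measurement on hand accounts for this step.

Going by these compounds, whether the methyl group or its ring position carries the step stays open, and 3-methylphenyl or 4-chlorophenyl on this carbonyl carbon would separate the two. How a plain phenyl, a 4-methoxyphenyl or a 4-aminophenyl would read here is also unknown.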